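Hydroxamic Acid Series: Thiophene Replaces Fluorophenyl on the Ketone

The source may hold more compounds than are shown below. What is called first, only, known or untested is meant among the compounds shown, and "the series" means these compounds.

Of the compounds shown here, two have been measured. Compound 1 `Cn1cc(/C=C/C(=O)c2ccc(F)cc2)cc1/C=C/C(=O)NO` carries a 4-fluorophenyl group on the ketone carbonyl; in an assay on isolated protein for inhibition of histone deacetylase HD1B (Zea mays) (on this read-out higher numbers stand for weaker inhibition and lower numbers for stronger inhibition), compound 1 gives 24900 nM. Compound 2 `Cn1cc(/C=C/C(=O)c2ccc(-c3ccccc3)cc2)cc1/C=C/C(=O)NO` differs only at the aromatic carbon, where phenyl replaces fluoro, and in this assay compound 2 gives 31800 nM. The step of a 1.3-fold higher number from compound 1 to compound 2 (0.11 log units; within the scatter) shows that exchanging the substituent on the aryl ring leaves the number unchanged within the scatter. Compound 1 thus stands lowest of the two numbers, but its neighbour lies within the scatter of it.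

Compound 3 `Cn1cc(/C=C/C(=O)c2ccsc2)cc1/C=C/C(=O)NO` is not yet measured. Relative to compound 1 the change is thiophen-3-yl in place of 4-fluorophenyl on a carbonyl carbon. No measured step covers the exchange of the whole aryl ring for a five-membered heteroaromatic ring; the only step shown, from compound 1 to compound 2, varied the aryl substituent and was within the scatter. On that basis no step beyond the scatter is expected in this assay, in either direction. For compound 3 the estimate is 25000 nM, with a range from 9000 nM to 70000 nM. The step expected from compound 1 to compound 3 is therefore a 1.0-fold higher number from compound 1 to compound 3 (0.00 log units; within the scatter).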

Compound 3, half-maximal inhibitory concentration: 22600 nM
Compound 3: middle estimate off by 1.1-fold (0.04 log units), on the high side; the range from low to high includes it.
By their numbers in this assay, from the lowest: compounds 3, 1 and 2 (each within the scatter of the next).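

Compound 3 shows that the whole ring on the carbonyl carbon can be exchanged, not only a substituent on it: in this assay, thiophen-3-yl in place of 4-fluorophenyl gives a 1.1-fold lower number from compound 1 to compound 3 (0.04 log units; within the scatter). The earlier step, a 1.3-fold higher number from compound 1 to compound 2 (0.11 log units; within the scatter), changed a substituent while keeping the six-membered aromatic ring of carbon only, whereas this change brings in a five-membered aromatic ring with 1 hetero atom, has 5 heavy atoms instead of 7, and adds 1 hydrogen-bond acceptor, all without a step beyond the scatter. No measurement shown here explains why the number stays within the scatter across this exchange.

The compounds shown leave open whether any group on this carbonyl carbon can move the number beyond the scatter, as every step so far lies within it. A cyclohexyl ring, a thiophen-2-yl ring, or an aryl ring bearing an amine or a carboxylic acid would test this position further, while a change elsewhere on the shared core, such as in the hydroxamic acid, remains a separate question.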